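The compounds below may be only part of what the source reports. "The series", "measured", "known", "first", "only" and "open" are said of these compounds alone.

Compound 1 `CCN1CCN(c2cc(C)c3cc(NC(=O)c4cccc(C)c4)ccc3n2)CC1` gives 7800 nM in a functional assay on MCF7 cells (Homo sapiens) for antiproliferative activity, read by MTT assay, with a stated time of 72 h (a lower number here means a stronger inhibitor, a higher number a weaker inhibitor), and stands second highest of the three numbers, between compound 2 `Cc1cc(NCCN2CCN(C)CC2)nc2ccc(NC(=O)c3ccc(Cl)c(Cl)c3)cc12` with 1700 nM and compound 3 `Cc1cc(N2CCCCC2)nc2ccc(NC(=O)c3ccc(Cl)c(Cl)c3)cc12` with 31100 nM. Among the measured compounds shown here, the only step between measured compounds, an 18-fold higher number from compound 2 to compound 3 (1.26 log units; beyond the scatter), alters the amine on the shared core and leaves the carbonyl carbon untouched. Compound 4 `CCN1CCN(c2cc(C)c3cc(NC(=O)c4ccc5ccccc5n4)ccc3n2)CC1` differs from compound 1 by quinolin-2-yl in place of 3-methylphenyl on a carbonyl carbon. For the measured compounds named here, no measured step bears on a change at the carbonyl carbon, so the direction and size of this one cannot be read from the series. For compound 4 a step of a 1.3-fold lower number from compound 1 to compound 4 (0.11 log units; within the scatter) is expected. Compound 4 is estimated at 6000 nM, within a range from 1500 nM to 25000 nM.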

Compound 4, half-maximal inhibitory concentration: 7060 nM
For compound 4 the middle estimate is 1.2-fold (0.07 log units) below the measured one; the measured number falls inside the stated range.
By their numbers in this assay, from the lowest: compound 2; then compounds 4 and 1 (each within the scatter of the next); then compound 3.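

In this assay, among the compounds shown here, a 1.1-fold lower number from compound 1 to compound 4 (0.04 log units; within the scatter) gives the first reading at the carbonyl carbon: 3-methylphenyl and quinolin-2-yl are not told apart here. Adding a second aromatic ring, a ring nitrogen and a hydrogen-bond acceptor at this position therefore leaves the number within the scatter, unlike the large step seen on changing the amine. No measured evidence bears on why this change is so small.

Still open, as far as these compounds go, is whether a non-aromatic group at the carbonyl carbon, such as a cyclohexyl ring or a longer alkyl chain, would give a step beyond the scatter. From the compounds shown here alone, whether quinolin-2-yl behaves the same alongside the (2-(4-methylpiperazin-1-yl)ethyl)amino group also remains unknown.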